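Paw edema series: compound 1 and its stereodefined analogue

A few compounds are considered here, and "the series" means these few. Any claim that something is new, unique, unknown or untested is made for them only; others in the source may bear on it.

Measured so far:
- compound 1, `Cc1ncc([N+](=O)[O-])n1CCOC(=O)c1cc(NC(=O)C(C)NC(=O)OCc2ccccc2)ccc1O`: 41.1%
- compound 2, `CC(=O)Nc1ccc(O)c(C(=O)O)c1`: 0%

In a functional assay on the whole organism (strain Wistar) for inhibition, with Rattus norvegicus as the target, read by paw edema, with stated times of 1 h and 4 h, at a dose of 10 mg/kg by the intraperitoneal route (on this read-out lower numbers stand for less inhibition and higher numbers for more inhibition at the one dose given (going by the name of the read-out)), compound 1 gives 41.1%, the highest of the two numbers recorded. Compound 2 gives 0% in the same test, a gap to compound 1 that lies beyond the usual scatter. Among the compounds with values here, the two measured compounds differ in more than one place, so no single-point step between them is recorded; their values show only that compound 1 sits well above compound 2.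

The next compound, compound 3, `Cc1ncc([N+](=O)[O-])n1CCOC(=O)c1cc(NC(=O)[C@H](C)NC(=O)OCc2ccccc2)ccc1O`, keeps every atom and bond of compound 1 and differs only in the drawing of one stereo element: the two compounds have the same atoms and bonds; at least one stereo element is drawn with a configuration in one of them and without one in the other: 1 of 1 stereo elements differ; a stereocentre at a saturated chain carbon is drawn without a configuration in compound 1 and S in compound 3. Nothing leaves and nothing enters. With no recorded step of this kind in the series, the expectation rests on the shared composition of compound 1 and compound 3: the step of a number 0.9 percentage points higher from compound 1 to compound 3 (within the scatter) is expected to be small, in no particular direction, and not beyond the scatter. Compound 3 is therefore estimated at 42%, with a range of 28% to 56%.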

Compound 3, a percentage reported as inhibition, in the whole organism at one dose (the size of the read-out at that dose, not a potency): 36.1%
The estimate for compound 3 lay 5.9 percentage points above the measured number; low and high end bracket the measured number.
By their numbers in this assay, from the lowest: compound 2; then compounds 3 and 1 (each within the scatter of the next).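

In this assay, within the data shown here, the first single-place step is a number 5 percentage points lower from compound 1 to compound 3 (within the scatter). Among these compounds, it gives the first direct reading at the stereocentre at a saturated chain carbon: on this read-out, at the one dose given, drawing that carbon as S does not separate compound 3 from compound 1, which is drawn without a configuration there, and no effect of this change can be claimed beyond the scatter. The comparison rests on a single structural point, with all atoms and bonds shared, and that point is: the fact that one of compounds 1 and 3 is drawn with a defined configuration and the other without, at the place where they differ

The compounds shown leave open how the R configuration at this carbon would read in this assay, and the drawing of compound 1 alone does not tell which forms its sample contains. They also leave open whether an ethyl group or a longer chain at this stereocentre would give a step beyond the scatter, since this comparison changes only how the stereocentre is drawn and says nothing about replacing any group attached to it.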